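The compounds below may be only part of what the source reports. "The series", "measured", "known", "first", "only" and "open" are said of these compounds alone.

Compound 1 `C=C1C(=O)[C@]23C[C@@]1(O)CC[C@H]2c1ccc(O)c(C)c1[C@@H]3Cn1cc(-c2ccc(C(F)(F)F)cc2)nn1` gives 1110 nM in a functional assay on A549 cells (Homo sapiens) for cytotoxicity, read by MTT assay, with a stated time of 4 days; on this read-out lower numbers stand for stronger inhibition and higher numbers for weaker inhibition.
Compound 2 `C=C1C(=O)[C@]23C[C@@]1(O)CC[C@H]2c1ccc(O)c(C)c1[C@@H]3Cn1cc(-c2ccccn2)nn1` gives 1570 nM in this assay.

Among the compounds with values here, on these two numbers, compound 2 sits within the scatter of compound 1, the only other value at hand. Compound 3 `C=C1C(=O)[C@]23C[C@@]1(O)CC[C@H]2c1ccc(O)c(C)c1[C@@H]3Cn1cc(-c2ccc(F)cc2)nn1` differs from compound 2 in one place: 4-fluorophenyl in place of pyridin-2-yl on an aromatic carbon. Within the data shown here, the one measured step, a 1.4-fold higher number from compound 1 to compound 2 (0.15 log units; within the scatter), also exchanged the ring on that aromatic carbon and stayed within the scatter, so a further exchange there is expected to move this assay little. The step is therefore expected to be a 1.2-fold lower number from compound 2 to compound 3 (0.08 log units; within the scatter), nothing beyond the scatter. Compound 3 is estimated at 1300 nM, ranging from 600 nM to 2800 nM.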

Compound 3, half-maximal inhibitory concentration: 940 nM
For compound 3 the middle estimate is 1.4-fold (0.14 log units) above the measured one; low and high end bracket the measured number.
By their numbers in this assay, from the lowest: compounds 3, 1 and 2 (each within the scatter of the next).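

The step of a 1.7-fold lower number from compound 2 to compound 3 (0.22 log units; within the scatter) exchanges the ring itself, and the step of a 1.2-fold lower number from compound 1 to compound 3 (0.07 log units; within the scatter) changes only the group carried on that ring, fluoro in place of trifluoromethyl; both stay within the scatter. In this assay, this position therefore tolerates all three aromatic rings shown, with or without a ring nitrogen, and none can be ranked above another. No measurement here explains this tolerance. Still open, from the compounds shown here alone, is whether a group of another kind on this carbon, such as a carboxylic acid, an amine or a longer alkyl chain, would move the number beyond the scatter.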